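A few compounds are considered here, and "the series" means these few. Any claim that something is new, unique, unknown or untested is made for them only; others in the source may bear on it.

Within the data shown here, in a functional assay on isolated protein for agonist activity at Glucose-dependent insulinotropic receptor (Homo sapiens), read by HTRF and cAMP accumulation (a lower number here means that less compound is needed, a higher number that more compound is needed for the effect), compound 2 `C[C@@H](CF)OC(=O)N1CCC(O[C@H]2CC[C@H](Oc3cnc(S(C)(=O)=O)cn3)CC2)CC1` gives 31.1 nM, the higher of the two numbers so far; compound 1 `CC(C)OC(=O)N1CCC(O[C@H]2CC[C@H](Oc3cnc(S(C)(=O)=O)cn3)CC2)CC1` gives 13.7 nM, and the shift a 2.3-fold higher number from compound 1 to compound 2 (0.36 log units; beyond the scatter) is the only measured step here. Compound 3 `CS(=O)(=O)c1cnc(O[C@H]2CC[C@H](OC3CCN(C(=O)C4(C(F)(F)F)CCCC4)CC3)CC2)cn1` differs from compound 2 by a group of 9 heavy atoms (6 carbon, 3 fluorine; one five-membered non-aromatic ring of carbon only) in place of a group of 5 heavy atoms (3 carbon, 1 oxygen, 1 fluorine; no ring), on a carbonyl carbon. Among the measured compounds shown here, that step from compound 1 to compound 2 concerns a different part of the molecule and does not bear on this exchange, so no measured step guides it. Compound 3 is therefore expected near compound 2 in this assay, with a wide range, an estimated step of a 1.2-fold lower number from compound 2 to compound 3 (0.09 log units; within the scatter) giving 25 nM (from 6 nM to 110 nM).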

Compound 3, half-maximal effective concentration: 38.4 nM
For compound 3 the middle estimate is 1.5-fold (0.19 log units) below the measured one; the range from low to high includes it.
By their numbers in this assay, from the lowest: compound 1; then compounds 2 and 3 (each within the scatter of the next).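

At the carbonyl carbon, the position tolerates a much larger group with a five-membered carbon ring and 0 hydrogen-bond acceptors in place of the fluorinated chain, a change of a 1.2-fold higher number from compound 2 to compound 3 (0.09 log units; within the scatter) in this assay. Against the unfluorinated group the same exchange gives a 2.8-fold higher number from compound 1 to compound 3 (0.45 log units; beyond the scatter), so the new group stays in the same nanomolar range but does not match compound 1. Nothing measured explains either step. Open, from the compounds shown here alone, is whether a plain cyclopentyl group without the three fluorines, or an amine at this carbonyl carbon, would match compound 1.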